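A few compounds are considered here, and "the series" means these few. Any claim that something is new, unique, unknown or untested is made for them only; others in the source may bear on it.

Three compounds were measured in an ADME assay on the whole organism with Oryza sativa as the target, tested at 1 uM; a lower number here means a stronger effect, a higher number a weaker effect of the compound at the concentration tested. Compound 1, `Cc1ccccc1NC(=O)N[C@@H](C)c1ccccc1`, gives 99% in this assay. Compound 3, `CCc1ccccc1NC(=O)N[C@@H](C)c1ccccc1`, gives 100%. These two are linked by one change, (methyl in place of hydrogen on a saturated chain carbon bound to an aromatic carbon), and the step it made is a number 1 percentage points higher from compound 1 to compound 3 (within the scatter). Compound 2, `Cc1ccc(NC(=O)N[C@H](C)c2ccccc2)cc1`, shares its atoms with compound 1 but joins them differently; the difference between the two cores is not broken down here. In this assay compound 2 gives 98%, which sits within the scatter of the other two values.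

Compound 4, `CCc1ccc(NC(=O)N[C@H](C)c2ccccc2)cc1`, has not yet been measured. Among the compounds with values here, it differs from compound 2 by methyl in place of hydrogen on a saturated chain carbon bound to an aromatic carbon, which is the same change as the one from compound 1 to compound 3. The writer expects the step from compound 2 to compound 4 to be a number 1 percentage points higher from compound 2 to compound 4 (within the scatter), essentially flat, because the same change gave a number 1 percentage points higher from compound 1 to compound 3 (within the scatter) and because compound 2 already stands at 98%, close to the top of the scale. The estimate for compound 4 is therefore 99%, with a range from 94% to 100%.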

Compound 4, a percentage reported as activity, at one concentration (the size of the read-out at that concentration, not a potency): 47%
Beside the measured number, compound 4's estimate is 52 percentage points above it; the whole stated range lies above it.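

In this assay, methyl in place of hydrogen on a saturated chain carbon bound to an aromatic carbon gave a number 51 percentage points lower from compound 2 to compound 4 (beyond the scatter). The change therefore did not carry over from one core to the other, and its outcome in this series depended on the core that received it: the same change on two cores in this assay, a number 1 percentage points higher (within the scatter) from compound 1 to compound 3 and a number 51 percentage points lower (beyond the scatter) from compound 2 to compound 4, 52 percentage points apart, beyond the scatter of two such steps. This shows only that the result on one core cannot be taken as a guide to the result on the other; with a single pair on each core, it gives no rule for further cores and does not show what makes the two cores respond differently.

The compounds shown leave open whether the effect seen with the ethyl group of compound 4 would extend to a longer chain such as propyl, or to a methoxy group or a chlorine atom in its place. Also open, as far as these compounds go, is how compound 4 would read at other concentrations, as this read-out is the size of the effect at one concentration and not a potency.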